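The source may hold more compounds than are shown below. What is called first, only, known or untested is meant among the compounds shown, and "the series" means these compounds.

Measured compounds in an assay on cells for displacement of a labelled ligand from C-X-C chemokine receptor type 4 (Homo sapiens), read by fluorescence and microscopy, with stated times of 10 min and 30 min; on this read-out higher numbers stand for an effect only at larger amounts of compound and lower numbers for an effect already at smaller amounts:
compound 1 `O=C(NCc1ccc(CNS(=O)(=O)c2ccc(F)cc2F)cc1)c1cncnc1` gives 1 nM
compound 2 `O=C(NCc1ccc(CNS(=O)(=O)c2ccccc2F)cc1)c1cc2ccccn2n1` gives 100 nM
compound 3 `Cc1nnsc1C(=O)NCc1ccc(CNS(=O)(=O)c2ccc(F)c(F)c2)cc1` gives 10 nM

Compound 1 has the lowest number of the three. Compound 3 is the nearest to it, and that gap lies beyond the usual scatter; compound 2 is the furthest from compound 1, also beyond the scatter. The three compounds differ in both the amide-linked heteroaryl group and the sulfonyl aryl group, so no single change has been isolated among them, and nothing measured speaks directly to the change now considered.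

Compound 4 `O=C(NCc1ccc(CNS(=O)(=O)c2ccc(F)cc2F)cc1)c1ncc[nH]1` keeps the sulfonamide side of compound 1 and alters only the heteroaryl group on the carbonyl carbon: 1H-imidazol-2-yl in place of pyrimidin-5-yl on a carbonyl carbon. Within the data shown here, no measured pair shows this change, so the expectation rests on compound 1 alone and on the spread seen across the other amide heteroaryl groups. A modest step upward in this assay, beyond the scatter, is expected, a 3.0-fold higher number from compound 1 to compound 4 (0.48 log units; beyond the scatter). Compound 4 is estimated at 3 nM, within a range of 0.7 nM to 15 nM.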

Compound 4, effective concentration (reported as EC, without a stated level of effect): > 1000 nM
Compound 4: no number, only a limit; the forecaster's own chance of this, stated with the estimate: 5%; middle value at least 330-fold (2.52 log units) from the limit.
By their numbers in this assay, from the lowest: compound 1; then compound 3; then compound 2. At a limit, above all of these: compound 4.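

In this assay, with the sulfonamide side held fixed, the heteroaryl group on the carbonyl carbon proves decisive on its own: 1H-imidazol-2-yl in place of pyrimidin-5-yl gives an at least 1000-fold higher number from compound 1 to compound 4 (3.00 log units; beyond the scatter). This is the only single-place step shown, whereas the earlier compounds differ in both the amide heteroaryl group and the sulfonyl aryl group and could not separate the two. The far end of this step is a limit of the assay and not a number: the limit of > 1000 nM in this assay, at which 1 of the 4 values shown sits.

The step changes ring size and the count of hydrogen-bond donors and acceptors together, so it cannot be assigned to any one of these. From the compounds shown here alone, whether 1-methyl-1H-imidazol-2-yl, pyridin-3-yl or plain phenyl on the same carbonyl carbon would stay close to compound 1 remains open.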